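Methoxy on the benzoyl end of the shared core

The source may report more compounds than this note shows. Statements on the series, on what has been measured and on what is new or still open speak of the compounds shown alone.

Measured so far in an ADME assay on HEK293 cells (Homo sapiens) for antiproliferative activity, read by MTT assay, with a stated time of 24 h; on this read-out lower numbers stand for stronger inhibition and higher numbers for weaker inhibition:
compound 1 `COc1ccc(C(=O)/C=C/c2cc(-c3ccc(OC)c(OC)c3)n3nc(-c4ccccc4)cc3n2)cc1` gives 40000 nM
compound 2 `COc1cc(-c2cc(C(=O)/C=C/c3ccc(C)cc3)nc3cc(-c4ccccc4)nn23)cc(OC)c1OC` gives 56100 nM
compound 3 `COc1cc(-c2cc(/C=C/C(=O)c3ccccc3)nc3cc(-c4ccccc4)nn23)cc(OC)c1OC` gives only a limit, >= 100000 nM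

Compound 3 therefore stands at the weak end of the numbers shown, and only as a limit of the assay, (the limit of >= 100000 nM in this assay, at which 1 of the 3 values shown sits). The one measured step that reaches it, an at least 1.7-fold higher number from compound 2 to compound 3 (0.25 log units; that floor lies within the scatter), is a floor that lies within the scatter, so the removal of the methyl group has not been shown to move the number.

The next compound, compound 4 `COc1ccc(C(=O)/C=C/c2cc(-c3cc(OC)c(OC)c(OC)c3)n3nc(-c4ccccc4)cc3n2)cc1`, differs from compound 3 by methoxy in place of hydrogen on an aromatic carbon. Cut one bond further out this reads benzoyl to (4-methoxyphenyl)carbonyl. The closest bearing is the step above: a small change on the same ring, para to a large group, gave no step beyond the scatter. Compound 1 carries the same (4-methoxyphenyl)carbonyl on a related core and gives a finite number, and compound 2 with the methyl analogue also gives a finite number.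

On that basis compound 4 is expected to show a modest drop, an at least 1.8-fold lower number from compound 3 to compound 4 (0.25 log units; that floor lies within the scatter), with a fair chance of another limit. The estimate for compound 4 in this assay is 55000 nM, between 25000 nM and 150000 nM.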

Compound 4, half-maximal inhibitory concentration: 79800 nM
The estimate for compound 4 lay 1.5-fold (0.16 log units) below the measured number; measured number inside the range.
By their numbers in this assay, from the lowest: compounds 1, 2 and 4 (each within the scatter of the next). At a limit, above all of these: compound 3.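

In this assay, methoxy in place of hydrogen on an aromatic carbon, para to a large group, gives an at least 1.2-fold lower number from compound 3 to compound 4 (0.09 log units; that floor lies within the scatter); the 4-methoxyphenyl form at this position thus has a measured number, but the change is not shown to move it. Compound 3 remains a limit of the assay, and the step can be read only as a floor because of that limit: the limit of >= 100000 nM in this assay, at which 1 of the 4 values shown sits.

The neighbouring changes also stay unresolved: 2-((4-methoxyphenyl)carbonyl)ethenyl in place of (2-(4-methylphenyl)ethenyl)carbonyl gives a 1.4-fold higher number from compound 2 to compound 4 (0.15 log units; within the scatter), and methoxy in place of hydrogen on an aromatic carbon gives a 2.0-fold higher number from compound 1 to compound 4 (0.30 log units; within the scatter), so neither change is shown to move the number in this assay.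

Going by these compounds, whether another group at this position, such as an amine, a carboxylic acid or a longer alkoxy chain, would give a step beyond the scatter remains open. On these data alone, with no number for compound 3, the full size of the methoxy step also remains open.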